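Swapping an Ester for a Sulfone: Expected Cytotoxicity

The compounds below may be only part of what the source reports. "The series", "measured", "known", "first", "only" and "open" are said of these compounds alone.

Compound 1, `C#CCOc1cc(/C=C/C(=O)c2ccc(OC)c3c2OC(C)(C)C=C3)ccc1OC`: in an ADME assay on L02 cells (Homo sapiens) for cytotoxicity, read by MTT assay (a higher number here means a weaker inhibitor, a lower number a stronger inhibitor), compound 1 gives > 10000 nM, a limit of the assay, not a number.
Compound 2, `COc1ccc(/C=C/C(=O)c2ccc(OC)c3c2OC(C)(C)C=C3)cc1OC(=O)C(C)C`: in this assay compound 2 gives > 10000 nM, again a limit and not a number.

Both measured compounds share one core and differ only in the group on an oxygen on an aromatic ring. The move from compound 1 to compound 2 is a step that the two limits leave unreadable from compound 1 to compound 2; both values sit at the limit of > 10000 nM in this assay, at which 2 of the 2 values shown sit, so this step cannot be read in either direction. Compound 2 therefore stands at the limit, with no measured number to place it more precisely.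

Compound 3 is `COc1ccc(/C=C/C(=O)c2ccc(OC)c3c2OC(C)(C)C=C3)cc1CS(C)(=O)=O`. Its change from compound 2 is (methylsulfonyl)methyl in place of (isopropylcarbonyl)oxy on an aromatic carbon. Among the measured compounds shown here, no measured step bears directly on this change, since the only available step is unreadable. For the measured compounds named here, the single readable fact is that every value so far sits at the limit. On that basis compound 3 is expected to stay near that limit, with an expected step that the limit leaves unreadable from compound 2 to compound 3, not beyond the scatter. Compound 3 is thus estimated at 15000 nM, in a range from 7000 nM to 40000 nM, most likely reported only as a limit.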

Compound 3, half-maximal inhibitory concentration: > 10000 nM
Compound 3 was reported as a limit; the forecaster's own chance of this, stated with the estimate: 85%; the middle value does not contradict the limit.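

In this assay compound 3 gives > 10000 nM, a limit and not a number. The steps linking compound 1, compound 2 and compound 3 therefore cannot be read: the limit of > 10000 nM in this assay, at which 3 of the 3 values shown sit. The compounds shown leave open how far apart these three lie, and whether their differing groups on the shared core change the result at all.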